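Swapping the chlorine position on a triazole-linked phenyl ring

The source may hold more compounds than are shown below. What is called first, only, known or untested is meant among the compounds shown, and "the series" means these compounds.

Compound 1 `Cc1ccc(-n2cc(-c3ccc(NS(=O)(=O)c4c[nH]c(=O)[nH]c4=O)cc3)nn2)cc1`: 5630 nM
Compound 2 `O=c1[nH]cc(S(=O)(=O)Nc2ccc(-c3cn(-c4ccccc4F)nn3)cc2)c(=O)[nH]1`: 8030 nM
Compound 3 `O=c1[nH]cc(S(=O)(=O)Nc2ccc(-c3cn(-c4cccc(Cl)c4)nn3)cc2)c(=O)[nH]1`: 2750 nM

Compound 3 stands lowest of the three in a functional assay on OVCAR-3 cells (Homo sapiens) for antiproliferative activity, read by MTT assay, with a stated time of 24 h; a lower number here means a stronger inhibitor, a higher number a weaker inhibitor; compound 1 lies a 2.0-fold lower number from compound 1 to compound 3 (0.31 log units; beyond the scatter) and compound 2 lies a 2.9-fold lower number from compound 2 to compound 3 (0.47 log units; beyond the scatter), both beyond the scatter. Compound 4 `O=c1[nH]cc(S(=O)(=O)Nc2ccc(-c3cn(-c4ccc(Cl)cc4)nn3)cc2)c(=O)[nH]1` differs from compound 3 by 4-chlorophenyl in place of 3-chlorophenyl on an aromatic nitrogen. Going by the values given here, no measured step changes only the chlorine position: both steps to compound 3 alter the substituent and its position together, so they speak only indirectly. The two ring positions without chlorine, seen in compound 1 and compound 2, gave higher numbers, but the substituents differed. The step to compound 4 is therefore expected to be small, a 1.4-fold higher number from compound 3 to compound 4 (0.14 log units; within the scatter), toward a slightly higher number. Compound 4 is estimated at 3800 nM, within 1600 nM to 9000 nM.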

Compound 4, half-maximal inhibitory concentration: 2160 nM
Estimate against measurement, compound 4: 1.8-fold (0.25 log units) above; the range from low to high includes it.
By their numbers in this assay, from the lowest: compounds 4 and 3 (each within the scatter of the next); then compounds 1 and 2 (each within the scatter of the next).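

In this assay, the step that changes only the chlorine position gives (a 1.3-fold lower number from compound 3 to compound 4 (0.10 log units; within the scatter)), so 4-chlorophenyl and 3-chlorophenyl cannot be told apart on this nitrogen. Chloro in place of methyl on an aromatic carbon is the cleanest substituent change so far and lies beyond the scatter (a 2.6-fold lower number from compound 1 to compound 4 (0.42 log units; beyond the scatter)), as does the change from 2-fluorophenyl (a 3.7-fold lower number from compound 2 to compound 4 (0.57 log units; beyond the scatter)). Nothing available explains these differences. On these data alone, it remains open whether a phenyl bearing an amine or a carboxylic acid on this nitrogen would keep the numbers of compound 3 and compound 4.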